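A few compounds are considered here, and "the series" means these few. Any claim that something is new, unique, unknown or untested is made for them only; others in the source may bear on it.

Measured in a functional assay on CHO cells for activation of 5-hydroxytryptamine receptor 1D (Homo sapiens), read by GTPgammaS binding; on this read-out lower numbers stand for smaller maximal responses and higher numbers for larger maximal responses:
compound 1 `c1ccc(CNCC2CCN(CCCc3c[nH]c4ccc(-n5cnnc5)cc34)CC2)cc1`: 101%
compound 2 `OC[C@H](NC1CCN(CCCc2c[nH]c3ccc(-n4ccnc4)cc23)CC1)c1ccccc1`: 74%
compound 3 `C[C@@H](NC1CCN(CCCc2c[nH]c3ccc(-n4cnnc4)cc23)CC1)c1ccccc1`: 90%

Compound 3 stands second highest of the three. Going by the values given here, compound 1 is nearest, the single measured step being a number 11 percentage points lower from compound 1 to compound 3 (beyond the scatter), brought by (1-phenylethyl)amino in place of (benzylamino)methyl on a saturated ring carbon. Compound 2 is furthest, its maximal response lying below that of compound 3 by more than the scatter.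

Compound 4 `C[C@@H](NC1CCN(CCCc2c[nH]c3ccc(-n4ccnc4)cc23)CC1)c1ccccc1` is not yet measured. It differs from compound 3 by 1H-imidazol-1-yl in place of 4H-1,2,4-triazol-4-yl on an aromatic carbon. Among the compounds with values here, no measured step carries this change alone. Compound 2 bears the 1H-imidazol-1-yl ring and compound 3 the 4H-1,2,4-triazol-4-yl ring, but the two also differ in the amine part, so their values give only a loose pointer, and it points downward. A step in this assay of modest size downward, or none beyond the scatter, is therefore expected. For compound 4 the estimate is 84%, with a range from 70% to 98%. The expected step is a number 6 percentage points lower from compound 3 to compound 4 (within the scatter).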

Compound 4, largest response reached (reported as efficacy), in percent of the reference or control that the assay uses: 65%
Compound 4: middle estimate off by 19 percentage points, on the high side, and the stated range ends above it.
By their numbers in this assay, from the lowest: compounds 4 and 2 (each within the scatter of the next); then compound 3; then compound 1.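

In this assay, the ring on the aromatic carbon now has a reading of its own: with the amine part unchanged, 1H-imidazol-1-yl in place of 4H-1,2,4-triazol-4-yl gives a number 25 percentage points lower from compound 3 to compound 4 (beyond the scatter). With the 1H-imidazol-1-yl ring kept, 1-phenylethyl in place of 2-hydroxy-1-phenylethyl on an amine nitrogen gives a number 9 percentage points lower from compound 2 to compound 4 (within the scatter), so the amine change shows no step beyond the scatter, and the earlier gap between compound 2 and compound 3 runs with the ring change. No measured property is available to explain the ring step.

Whether the ring step holds with other amine parts rests on this single matched pair, and compound 1 has no 1H-imidazol-1-yl partner. As far as these compounds go, how a 1H-pyrazol-1-yl or 1H-tetrazol-1-yl ring on the same aromatic carbon would compare remains open.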